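Swapping acetyl for cyano on the sulfonyl-bearing chain carbon

This account rests on a few compounds, and the source may have more. Where it says the series, first, only, none or still open, it means among the compounds named here.

Measured so far:
Compound 1 `COc1ccc(-c2[nH]c3ccc(OC)cc3c2/C=C(\C#N)S(=O)(=O)c2ccccc2)cc1`: 612 nM
Compound 2 `CC(=O)/C(=C\c1c(-c2ccccc2)[nH]c2ccccc12)S(=O)(=O)c1ccccc1`: 1700 nM

In a functional assay on SNB-75 cells (Homo sapiens) for inhibition, read by sulforhodamine B assay, with a stated time of 48 h (on this read-out lower numbers stand for stronger inhibition of growth and higher numbers for weaker inhibition of growth), compound 2 gives 1700 nM. Among the two measured compounds it has the highest number; its only neighbour, compound 1, gives 612 nM, a gap that goes beyond the scatter. The two differ in several places at once, so nothing can be read from them about any single change.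

Compound 3 `N#C/C(=C\c1c(-c2ccccc2)[nH]c2ccccc12)S(=O)(=O)c1ccccc1` differs from compound 2 in one place: cyano in place of acetyl on a double-bonded chain carbon bound to a double-bonded chain carbon and a sulfonyl sulfur. Going by the values given here, no pair of measured compounds shows this step on its own, so its size is unknown. The move is expected to lower the number somewhat, yet with wide uncertainty, since compound 1 carries the same cyano group on an otherwise different scaffold. Compound 3 is expected to give 1000 nM, within 400 nM to 2500 nM, a step of a 1.7-fold lower number from compound 2 to compound 3 (0.23 log units; within the scatter) that may still fall within scatter.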

Compound 3, concentration for 50% growth inhibition: 1700 nM
For compound 3 the middle estimate is 1.7-fold (0.23 log units) below the measured one; measured number inside the range.
By their numbers in this assay, from the lowest: compound 1; then compounds 2 and 3 (each within the scatter of the next).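

In this assay, putting cyano in place of acetyl on a double-bonded chain carbon bound to a double-bonded chain carbon and a sulfonyl sulfur gives no change at the digits printed from compound 2 to compound 3 (within the scatter). Going by these compounds alone, this is the first single-place change in the set, and it shows that on the core shared by compound 2 and compound 3 this position holds either group with no change in the read-out beyond the scatter. No measurement at hand bears on why the two groups read alike.

On these data alone, whether the same swap would behave the same way on the core of compound 1 stays open, since that compound differs from both others in more than one place. Also open, as far as these compounds go, is how an amine or a carboxylic acid would read on this chain carbon.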